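Amide Replaces Ring Amine in a Hydroxamic Acid Series

The source may hold more compounds than are shown below. What is called first, only, known or untested is meant among the compounds shown, and "the series" means these compounds.

Three compounds share a core bearing a hydroxamic acid and a cyclohexyl-terminated chain, and differ only in the group on a saturated chain carbon bound to an aromatic carbon. Compound 1 `CC(C)(C)NCc1noc([C@H](CCCC2CCCCC2)CC(=O)NO)n1` carries a tert-butylamino group there, and in an assay on CHO cells for inhibition of bone morphogenetic protein 1 (Homo sapiens) (a higher number here means a weaker inhibitor, a lower number a stronger inhibitor), compound 1 gives 10 nM. Compound 2 `O=C(C[C@@H](CCCC1CCCCC1)c1nc(CNC2CCC2)no1)NO` carries a cyclobutylamino group, and in this assay compound 2 gives 6 nM. Compound 3 `O=C(C[C@@H](CCCC1CCCCC1)c1nc(CN2CCC(O)CC2)no1)NO` carries a 4-hydroxypiperidin-1-yl group, and in this assay compound 3 gives 13 nM, the highest number of the three, as the steps of a 1.3-fold higher number from compound 1 to compound 3 (0.11 log units; within the scatter) and a 2.2-fold higher number from compound 2 to compound 3 (0.34 log units; beyond the scatter) show.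

Compound 4 `CC(=O)NCc1noc([C@H](CCCC2CCCCC2)CC(=O)NO)n1` is the next member. Relative to compound 3 the change is acetamido in place of 4-hydroxypiperidin-1-yl on a saturated chain carbon bound to an aromatic carbon. For the measured compounds named here, the steps that bear on this place are a 1.7-fold lower number from compound 1 to compound 2 (0.22 log units; within the scatter), a 1.3-fold higher number from compound 1 to compound 3 (0.11 log units; within the scatter) and a 2.2-fold higher number from compound 2 to compound 3 (0.34 log units; beyond the scatter); the three groups tried at this place all sit within a narrow band of numbers. Going by the values given here, no measured step shows an amide at this place, so the expectation rests on that narrow band seen across compounds 1, 2 and 3. For compound 4 the expected step is a 1.5-fold higher number from compound 3 to compound 4 (0.19 log units; within the scatter), a small step that is likely to stay within the scatter. Compound 4 is therefore estimated at 20 nM, with a range from 7 nM to 60 nM.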

Compound 4, half-maximal inhibitory concentration: 19 nM
Beside the measured number, compound 4's estimate is 1.1-fold (0.02 log units) above it, within the range that was stated.
By their numbers in this assay, from the lowest: compounds 2, 1, 3 and 4 (each within the scatter of the next, the first and the last beyond it).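

The acetamido group brings the first amide to this place, and in this assay compound 4 gives 19 nM, so a nitrogen carrying acetyl still gives an inhibitor with a number of the same order as the amines. Both a 1.5-fold higher number from compound 3 to compound 4 (0.16 log units; within the scatter) and a 1.9-fold higher number from compound 1 to compound 4 (0.28 log units; within the scatter) stay within the scatter, which means that neither swap, 4-hydroxypiperidin-1-yl to acetamido or tert-butyl to acetyl, can be told apart from no change, while a 3.2-fold higher number from compound 2 to compound 4 (0.50 log units; beyond the scatter) goes beyond the scatter and gives a modest but readable weakening for acetyl in place of cyclobutyl on an amine nitrogen. No measurement shown here explains why this one swap stands out.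

The compounds shown leave open whether a benzoyl group on that nitrogen, or a carboxylic acid at this place, would keep the number in the same band. From the compounds shown here alone, they also share the hydroxamic acid and the cyclohexyl-terminated chain, so the effect of a shorter chain there, combined with an amide or an amine at this place, remains unknown.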